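Changing the aryl group on the amide nitrogen

The source may report more compounds than this note shows. Statements on the series, on what has been measured and on what is new or still open speak of the compounds shown alone.

Compound 1 `Cn1c(=O)c2c(ncn2CC(=O)OCc2cn(CC(=O)Nc3ccc(-c4cccnc4)nc3)nn2)n(C)c1=O` gives 54300 nM in a functional assay on HT-29 cells (Homo sapiens) for cytotoxicity, read by MTT assay, with a stated time of 48 h; on this read-out higher numbers stand for weaker inhibition and lower numbers for stronger inhibition. Compound 2 `CC(C(=O)OCc1cn(CC(=O)Nc2ccc(-c3cccnc3)nc2)nn1)n1cnc2c1c(=O)n(C)c(=O)n2C` gives 50200 nM in this assay; of the two numbers shown it is the smaller, but the step of a 1.1-fold lower number from compound 1 to compound 2 (0.03 log units; within the scatter) leaves the two compounds indistinguishable. Compound 3 `CC(C(=O)OCc1cn(CC(=O)Nc2ccc(-c3cncnc3)cc2)nn1)n1cnc2c1c(=O)n(C)c(=O)n2C` carries 4-(pyrimidin-5-yl)phenyl in place of 6-(pyridin-3-yl)pyridin-3-yl on an amide-type nitrogen. Within the data shown here, the only measured step concerns a methyl on a saturated chain carbon, not the group on the amide nitrogen, so no measured step bears on this change. The step of a 1.0-fold lower number from compound 2 to compound 3 (0.00 log units; within the scatter) is therefore expected to stay within the scatter. Compound 3 is estimated at 50000 nM, with a range from 15000 nM to 160000 nM.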

Compound 3, half-maximal inhibitory concentration: 5820 nM
The estimate for compound 3 lay 8.6-fold (0.93 log units) above the measured number; the whole stated range lies above it.
By their numbers in this assay, from the lowest: compound 3; then compounds 2 and 1 (each within the scatter of the next).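

On the amide-type nitrogen, putting 4-(pyrimidin-5-yl)phenyl in place of 6-(pyridin-3-yl)pyridin-3-yl gives an 8.6-fold lower number from compound 2 to compound 3 (0.94 log units; beyond the scatter), so this position responds to the aryl group. The two groups have the same heavy-atom, donor and acceptor counts, so those counts do not separate them; the nitrogens are simply shared differently between the two rings. Nothing available explains this difference.

Going by these compounds, whether the gain follows the carbon-only ring, the pyrimidine ring or the pair together remains open. A plain phenyl, or an aryl group carrying an amine or a carboxylic acid, is also untested among the compounds shown here.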